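Working notes: compound 4 in the oral rat series

This account rests on a few compounds, and the source may have more. Where it says the series, first, only, none or still open, it means among the compounds named here.

Measured so far:
compound 1, `O=C1NC(=O)/C(=C/c2ccc(OCCSc3nnc(-c4ccccc4)[nH]3)cc2)S1`: in a functional assay on the whole organism (plasma, strain Wistar) with Rattus norvegicus as the target, with a stated time of 15 days, at a dose of 3 mg/kg by the oral route (on this read-out lower numbers stand for a weaker effect and higher numbers for a stronger effect at the one dose given), compound 1 gives 10.4%.
compound 2, `O=C1NC(=O)/C(=C/c2ccc(OCCSc3nnc(Cc4ccccc4)[nH]3)cc2)S1`: in this assay compound 2 gives 18.3%.
compound 3, `O=C1NC(=O)/C(=C/c2ccc(OCCSc3nnc(-c4ccccc4[N+](=O)[O-])[nH]3)cc2)S1`: in this assay compound 3 gives 14.6%.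

Compound 3 stands second highest of the three numbers; the nearest number is that of compound 2 and the furthest that of compound 1. The gaps are a number 3.7 percentage points lower from compound 2 to compound 3 (within the scatter) and a number 4.2 percentage points higher from compound 1 to compound 3 (within the scatter), both within the scatter, so no order among the three is established.

Compound 4, `COc1ccc(-c2nnc(SCCOc3ccc(/C=C4\SC(=O)NC4=O)cc3)[nH]2)cc1`, differs from compound 3 in one place: 4-methoxyphenyl in place of 2-nitrophenyl on an aromatic carbon. Among the compounds with values here, no measured step exchanges one substituted phenyl for another at this carbon. The steps that touch the position are a number 4.2 percentage points higher from compound 1 to compound 3 (within the scatter) and a number 3.7 percentage points lower from compound 2 to compound 3 (within the scatter), and the remaining step of a number 7.9 percentage points higher from compound 1 to compound 2 (within the scatter) also stays within the scatter. On that footing no step beyond the scatter is expected in this assay for compound 4, and the expected step is a number 0.6 percentage points lower from compound 3 to compound 4 (within the scatter). Compound 4 is therefore estimated at about 14%, with an expected range from 5% to 24%.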

Compound 4, a percentage reported as activity, at one dose (the size of the read-out at that dose, not a potency): 41.3%
The estimate for compound 4 lay 27.3 percentage points below the measured number; measured number above the stated range.
By their numbers in this assay, from the lowest: compounds 1, 3 and 2 (each within the scatter of the next); then compound 4.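

In this assay, the group on this aromatic carbon of the five-membered aromatic ring with 3 nitrogen now shifts the read-out beyond the scatter, which no earlier exchange there did: a number 26.7 percentage points higher from compound 3 to compound 4 (beyond the scatter), a number 23 percentage points higher from compound 2 to compound 4 (beyond the scatter) and a number 30.9 percentage points higher from compound 1 to compound 4 (beyond the scatter). A single methoxy in place of hydrogen on the phenyl group is enough for this, whereas the nitro of the 2-nitrophenyl group in compound 3 was not. Nothing available accounts for this difference.

Going by these compounds, whether another group in place of the methoxy, such as an ethoxy, a hydroxy or an amine, would carry the same gain stays open. The compounds shown also leave open whether a methoxy elsewhere on the phenyl ring would do so.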